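A Tetrazole in Place of the Hydroxyphenyl Arm

The compounds below may be only part of what the source reports. "The series", "measured", "known", "first", "only" and "open" are said of these compounds alone.

Compound 2 `O=C(CCCCCCc1ccccc1)c1ncc(-c2ccc(O)cc2)o1` is one of three close relatives that share a core and differ only in the group on an aromatic carbon of the five-membered ring. In an assay (Rattus norvegicus) for inhibition of Fatty-acid amide hydrolase 1 (Homo sapiens) (on this read-out higher numbers stand for weaker inhibition and lower numbers for stronger inhibition), compound 2 gives 140 nM, the highest of the three numbers. Compound 1 `COC(=O)c1ccc(-c2cnc(C(=O)CCCCCCc3ccccc3)o2)cc1` gives 40 nM, and compound 3 `NS(=O)(=O)c1ccc(-c2cnc(C(=O)CCCCCCc3ccccc3)o2)cc1` gives 10 nM, so compound 2 is the weakest inhibitor of the set: a 3.5-fold higher number from compound 1 to compound 2 (0.54 log units; beyond the scatter), a 14-fold lower number from compound 2 to compound 3 (1.15 log units; beyond the scatter), and a 4.0-fold lower number from compound 1 to compound 3 (0.60 log units; beyond the scatter).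

Compound 4 `O=C(CCCCCCc1ccccc1)c1ncc(-c2nnn[nH]2)o1` has not yet been measured. It differs from compound 2 in one place: 1H-tetrazol-5-yl in place of 4-hydroxyphenyl on an aromatic carbon.

The measured steps all swap one group on the 4-hydroxyphenyl for another while keeping that ring; none removes the ring itself, as this change does. They show that the group at this position can move the number by a modest to large amount in either direction, but they give no direct guide to a 1H-tetrazol-5-yl. Since compound 2 already sits at the weak end, and the change is larger than any step measured, a modest move is expected, with wide uncertainty, toward a higher number: a 2.1-fold higher number from compound 2 to compound 4 (0.33 log units; beyond the scatter). Compound 4 is therefore estimated at 300 nM, expected to fall between 60 nM and 1500 nM.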

Compound 4, inhibition constant: 63 nM
Compound 4: the middle estimate sits 4.8-fold (0.68 log units) above what was measured, and the stated range covers the measured number.
By their numbers in this assay, from the lowest: compound 3; then compounds 1 and 4 (each within the scatter of the next); then compound 2.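

Removing the six-membered ring altogether does not cost inhibition in this assay: replacing the 4-hydroxyphenyl with a 1H-tetrazol-5-yl gives a 2.2-fold lower number from compound 2 to compound 4 (0.35 log units; beyond the scatter), a modest gain that lies beyond the scatter. The earlier compounds shown here all kept that carbon-only ring and varied only the group on it, so they could not show that this position also accepts a smaller five-membered ring with 4 hetero atoms, 5 heavy atoms in place of 7. Nothing available here explains the gain, so the data describe the change without accounting for it.

The compounds shown leave open which part of the change matters: the loss of the six-membered ring, the gain of ring nitrogens, or the 3 hydrogen-bond acceptors in place of 1. An unsubstituted phenyl, a plain hydrogen, or a carboxylic acid on the same aromatic carbon of the five-membered ring would help separate these possibilities, as would a triazole, which keeps the five-membered ring but has one nitrogen fewer.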